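Adding a Third Methoxy Group to a Weak Quinoxaline Sulfone

The compounds below may be only part of what the source reports. "The series", "measured", "known", "first", "only" and "open" are said of these compounds alone.

Of the compounds shown here, three from a shared core have been measured in a functional assay on HL-60 cells (Homo sapiens) for cytotoxicity, read by MTT assay, with a stated time of 72 h; on this read-out higher numbers stand for weaker inhibition and lower numbers for stronger inhibition. Among the compounds with values here, compound 1 `COc1cc(Nc2nc3ccccc3nc2S(=O)(=O)c2ccc(C)cc2)cc(OC)c1OC` gives 320 nM, and compound 2 `COc1ccc(S(=O)(=O)c2nc3ccccc3nc2Nc2cc(OC)c(OC)c(OC)c2)cc1` gives 680 nM; the only measured single step is a 2.1-fold higher number from compound 1 to compound 2 (0.33 log units; beyond the scatter). Compound 3 `COc1cc(Nc2nc3ccccc3nc2S(=O)(=O)c2ccc(F)cc2)cc(OC)c1` gives 2360 nM, the highest number of the three, above that of compound 2 and further above that of compound 1, both gaps beyond the scatter.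

Compound 4 `COc1cc(Nc2nc3ccccc3nc2S(=O)(=O)c2ccc(F)cc2)cc(OC)c1OC` differs from compound 3 by methoxy in place of hydrogen on an aromatic carbon, so that compound 4 carries the same three methoxy groups as compounds 1 and 2. Within the data shown here, no measured step covers this exact change. Among the measured compounds shown here, the numbers for compound 1 and compound 2, the two compounds that already hold three methoxy groups, both lie well under that of compound 3, and this is the only guide. On that basis the expectation for compound 4 is a step of a 4.7-fold lower number from compound 3 to compound 4 (0.67 log units; beyond the scatter) in this assay, toward a lower number. The estimate for compound 4 is 500 nM, with a range from 200 nM to 1500 nM.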

Compound 4, half-maximal inhibitory concentration: 4790 nM
Beside the measured number, compound 4's estimate is 9.6-fold (0.98 log units) below it; measured number above the stated range.
By their numbers in this assay, from the lowest: compound 1; then compound 2; then compound 3; then compound 4.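

In this assay, a methoxy group ortho to two methoxy groups does not lower the number when fluoro stands on the sulfone's aromatic ring: the change gives a 2.0-fold higher number from compound 3 to compound 4 (0.31 log units; beyond the scatter) instead. With all three methoxy groups in place, the group on that other ring matters more, since fluoro in place of methoxy gives a 7.0-fold higher number from compound 2 to compound 4 (0.85 log units; beyond the scatter) and fluoro in place of methyl gives a 15-fold higher number from compound 1 to compound 4 (1.18 log units; beyond the scatter), so three methoxy groups alone do not bring a low number. Nothing available explains why the added methoxy group raises the number here.

As far as these compounds go, whether the same methoxy step also raises the number with methyl or methoxy in place of fluoro stays open. So does the outcome with an amine or a longer ethoxy chain at the new position, or with chloro in place of fluoro.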